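Methoxymethyl in place of methanesulfonamido on the ring

The source may hold more compounds than are shown below. What is called first, only, known or untested is meant among the compounds shown, and "the series" means these compounds.

Compound 2 `CS(=O)(=O)NC1CN(CC2CCN(Cc3ccccc3)CC2)C(=O)N(c2cccc(C(=N)N)c2)C1` gives 350 nM in an assay on cells (Hepatocyte) for inhibition of Hepatocyte growth factor activator serine protease (Homo sapiens), read by fluorescence (a higher number here means a weaker inhibitor, a lower number a stronger inhibitor), the lowest of the two numbers in hand; compound 3 `CC1CN(Cc2ccc(C(=N)N)cc2)C(=O)N(C2CCN(Cc3ccccc3)CC2)C1` gives 39600 nM. Compound 1 `CC1CN(Cc2cccc(C(=N)N)c2)C(=O)N(C2CCN(Cc3ccccc3)CC2)C1` reaches only the limit of this assay, > 100000 nM, and that limit is described as the limit of > 100000 nM in this assay, at which 1 of the 3 values shown sits. For the measured compounds named here, the one measured step, an at least 2.5-fold lower number from compound 1 to compound 3 (0.40 log units; beyond the scatter), moves the amidine on the aromatic ring and has nothing to say about the saturated ring carbon.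

Compound 4 `COCC1CN(CC2CCN(Cc3ccccc3)CC2)C(=O)N(c2cccc(C(=N)N)c2)C1` differs from compound 2 by methoxymethyl in place of methanesulfonamido on a saturated ring carbon. Going by the values given here, no measured step concerns this position or this exchange, so the expectation rests only on the size of the groups counted above and on the values of compound 2 and compound 3, with no hydrogen-bond donor left at that carbon. A loss of potency of moderate size is expected, with the direction uncertain and wide bounds. Compound 4 is estimated at 1500 nM, between 300 nM and 8000 nM, which means an expected step of a 4.3-fold higher number from compound 2 to compound 4 (0.63 log units; beyond the scatter).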

Compound 4, inhibition constant: 160 nM
Compound 4: the middle estimate sits 9.4-fold (0.97 log units) above what was measured; the measured number lies below the stated range.
By their numbers in this assay, from the lowest: compound 4; then compound 2; then compound 3. At a limit, above all of these: compound 1.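

In this assay, for the compounds shown here, methoxymethyl in place of methanesulfonamido on this saturated ring carbon gives a 2.2-fold lower number from compound 2 to compound 4 (0.34 log units; beyond the scatter), the first measured step at this position, and it is modest. It shows that compound 4 keeps a sub-micromolar-range number without the sulfonyl group, and that a smaller group with 0 hydrogen-bond donors, entering for one with 1, does not cost potency in this pair. Nothing in the data shown accounts for the direction of this step.

The compounds shown leave open whether an amine, a carboxylic acid or a longer ether chain on this saturated ring carbon would move the number further. Going by these compounds, whether the same exchange gives a like step on another core, such as that of compound 3, also remains open.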